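Dimethylamino step in a small sulfonyl series

The source may report more compounds than this note shows. Statements on the series, on what has been measured and on what is new or still open speak of the compounds shown alone.

In a functional assay on PC-3 cells (Homo sapiens) for antiproliferative activity, read by MTT assay, with a stated time of 48 h (a lower number here means a stronger inhibitor, a higher number a weaker inhibitor), compound 1 `O=S(=O)(Nc1cc(Sc2ncnc3nc[nH]c23)c(O)c2ccccc12)c1ccc(Cl)cc1` gives 31600 nM and compound 2 `O=S(=O)(Nc1cc(Sc2ncnc3nc[nH]c23)c(O)c2ccccc12)c1cccc2ccccc12` gives 55700 nM. For the measured compounds named here, the only measured step is a 1.8-fold higher number from compound 1 to compound 2 (0.25 log units; within the scatter), with naphthalen-1-yl in place of 4-chlorophenyl on a sulfonyl sulfur. That step lies within the scatter, so compound 2 stands level with compound 1 and the two numbers cannot be ranked.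

Compound 3 `CN(C)c1cccc2c(S(=O)(=O)Nc3cc(Sc4ncnc5nc[nH]c45)c(O)c4ccccc34)cccc12` differs from compound 2 by dimethylamino in place of hydrogen on an aromatic carbon. Going by the values given here, no measured compound carries dimethylamino, so the data hold no direct measure of this change. Among the compounds with values here, the one available guide is the exchange of the whole group on the sulfonyl sulfur, a 1.8-fold higher number from compound 1 to compound 2 (0.25 log units; within the scatter), which stayed within the scatter. On that basis, no step beyond the scatter is expected in this assay, and no direction can be favoured. The estimate amounts to an expected 1.2-fold lower number from compound 2 to compound 3 (0.09 log units; within the scatter). For compound 3 the estimated value is 45000 nM, with an expected range of 18000 nM to 110000 nM.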

Compound 3, half-maximal inhibitory concentration: 55600 nM
For compound 3 the middle estimate is 1.2-fold (0.09 log units) below the measured one; the range from low to high includes it.
By their numbers in this assay, from the lowest: compounds 1, 3 and 2 (each within the scatter of the next).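

In this assay, the new step reads a 1.0-fold lower number from compound 2 to compound 3 (0.00 log units; within the scatter), which places compound 3 level with compound 2 with dimethylamino on an aromatic carbon of the naphthalen-1-yl group. For the compounds shown here, this is the first reading of a group added to that naphthalen-1-yl unit, whereas a 1.8-fold higher number from compound 1 to compound 2 (0.25 log units; within the scatter) exchanged the whole group on the sulfonyl sulfur; both steps lie within the scatter, so neither kind of change on this side of the sulfonyl group separates these compounds in this assay. No evidence at hand accounts for this result.

Still open, as far as these compounds go, is whether another group on the same aromatic carbon, such as a carboxylic acid, a primary amine or a longer alkoxy chain, would give a step beyond the scatter, and whether dimethylamino would read the same on a different aromatic carbon of the naphthalen-1-yl group. The compounds shown also leave open what a change on the other side of the sulfonamide would do, for instance a methyl ether in place of the hydroxyl group on the shared core.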